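Acyl groups on the ring nitrogen of compound 3

A few compounds are considered here, and "the series" means these few. Any claim that something is new, unique, unknown or untested is made for them only; others in the source may bear on it.

Compound 3 `CC(C)Nc1nc2c(nc1N1CCC(Oc3ccc(F)cc3F)CC1)C=CNC2` stands at the high end of the three numbers seen so far in a functional assay on CHO-K1 cells for agonist activity at G-protein coupled receptor 6 (Homo sapiens), read by TR-FRET and cAMP accumulation, with a stated time of 20 h; a higher number here means that more compound is needed for the effect, a lower number that less compound is needed: compound 3 gives 100000 nM. Its nearest neighbour, compound 2 `CCC(=O)N1C=Cc2nc(N3CCN(Cc4ccc(F)cc4F)CC3)c(NC(C)C)nc2C1`, gives 30000 nM in this assay, a gap beyond the usual scatter. Compound 1 `CN(C)C(=O)c1ccc2nc(NC3CC3)c(N3CCN(Cc4cc(Cl)ccc4Cl)CC3)nc2c1`, built on a different core, gives 90 nM in this assay, far below both. Within the data shown here, compound 2 carries an acyl group on the ring nitrogen that compound 3 leaves bare and gives the lower number of the two, but compound 2 also differs in the amine attached to the core, so no single step isolates the effect of that acylation.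

Compound 4 `COC(=O)N1C=Cc2nc(N3CCC(Oc4ccc(F)cc4F)CC3)c(NC(C)C)nc2C1` takes the step from compound 3: methoxycarbonyl in place of hydrogen on an amine nitrogen in a ring. Among the measured compounds shown here, no measured pair differs in only this place. Since compound 2 changes two things at once relative to compound 3, only a modest step toward a lower number is expected here, a 2.0-fold lower number from compound 3 to compound 4 (0.30 log units; within the scatter). For compound 4 the estimate in this assay is 50000 nM, with a range from 15000 nM to 150000 nM. A result reported only as a limit rather than a number is expected to remain a real possibility for compound 4.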

Compound 4, half-maximal effective concentration: 158000 nM
Beside the measured number, compound 4's estimate is 3.2-fold (0.50 log units) below it; measured number above the stated range.
By their numbers in this assay, from the lowest: compound 1; then compound 2; then compounds 3 and 4 (each within the scatter of the next).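

In this assay, among these compounds, the first single-place step at this ring nitrogen is a 1.6-fold higher number from compound 3 to compound 4 (0.20 log units; within the scatter) and lies within the scatter. Methoxycarbonyl in place of hydrogen on an amine nitrogen in a ring therefore leaves no change in this read-out that can be told from repeat-measurement noise, and this carbonyl-bearing group alone does not bring the number toward the much lower value of compound 1, which in any case sits on a different core and is linked to this pair by no single-place step. No data on hand bear on why this step has the size it has.

Still open, as far as these compounds go, is whether a group of another kind on this nitrogen, such as a plain methyl, a benzyl or a chain ending in a carboxylic acid, would give a step beyond the scatter. Among the compounds shown here, also open is whether methoxycarbonyl behaves the same way when the amine attached to the shared core is the one carried by compound 2, and no single step yet separates the contributions of the two places in which compound 2 differs from compound 3.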